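From Trifluoromethyl to Chloro in a Small Series

This account rests on a few compounds, and the source may have more. Where it says the series, first, only, none or still open, it means among the compounds named here.

Compound 1 `N#Cc1cc(Cl)ccc1NC(=O)c1ccc2cccnc2c1O` gives 3540 nM
Compound 2 `N#Cc1ccc(NC(=O)c2ccc3cccnc3c2O)cc1` gives 2320 nM
Compound 3 `O=C(Nc1ccc(C(F)(F)F)cc1)c1ccc2cccnc2c1O` gives 3510 nM

In a functional assay on KG-1 cells (Homo sapiens) for cytotoxicity, read by luminescence and CellTiter-Glo, with a stated time of 3 days (a lower number here means a stronger inhibitor, a higher number a weaker inhibitor), compound 3 gives 3510 nM and sits within the scatter of both compound 1 and compound 2, so no order among them can be claimed. Compound 4 `O=C(Nc1ccc(Cl)cc1)c1ccc2cccnc2c1O` has chloro in place of trifluoromethyl on an aromatic carbon. Among the measured compounds shown here, one measured step bears on this, with trifluoromethyl taking the place of cyano on an aromatic carbon (a 1.5-fold higher number from compound 2 to compound 3 (0.18 log units; within the scatter)), and it stayed within the scatter. For the measured compounds named here, with only this one step as a guide, no change beyond the scatter is expected in this assay (a 1.2-fold lower number from compound 3 to compound 4 (0.07 log units; within the scatter)). The estimate for compound 4 is 3000 nM (expected range 1500 nM to 6000 nM).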

Compound 4, half-maximal inhibitory concentration: 3300 nM
Compound 4: middle estimate off by 1.1-fold (0.04 log units), on the low side; the range from low to high includes it.
By their numbers in this assay, from the lowest: compounds 2, 4, 3 and 1 (each within the scatter of the next).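

Chloro in place of trifluoromethyl on an aromatic carbon stays within the scatter in this assay (a 1.1-fold lower number from compound 3 to compound 4 (0.03 log units; within the scatter)), and so does chloro in place of cyano (a 1.4-fold higher number from compound 2 to compound 4 (0.15 log units; within the scatter)). Cyano, trifluoromethyl and chloro at this position therefore cannot be told apart here, and hydrogen in place of cyano at another aromatic carbon also stays within the scatter (a 1.1-fold lower number from compound 1 to compound 4 (0.03 log units; within the scatter)). No supporting measurement explains these results. As far as these compounds go, whether an amine or a carboxylic acid at this position would give a step beyond the scatter remains open.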